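The source may hold more compounds than are shown below. What is called first, only, known or untested is meant among the compounds shown, and "the series" means these compounds.

Measured compounds in a functional assay on A549 cells (Homo sapiens) for antiproliferative activity, read by CCK-8 assay, with a stated time of 72 h; a higher number here means a weaker inhibitor, a lower number a stronger inhibitor:
compound 1, `O=C(Nc1cccc(-c2oc3cc(-c4ccc(F)cc4)ccc3c(=O)c2O)c1)c1ccccc1F`, 4410 nM;
compound 2, `O=C(Nc1cccc(-c2oc3cc(-c4ccc(F)cc4)ccc3c(=O)c2O)c1)c1ccc(F)cc1F`, 20500 nM;
compound 3, `Cc1ccccc1C(=O)Nc1cccc(-c2oc3cc(-c4ccc(F)cc4)ccc3c(=O)c2O)c1`, 17600 nM.

Among these three, compound 3 stands second highest. Its nearest neighbour is compound 2, separated by a 1.2-fold lower number from compound 2 to compound 3 (0.07 log units; within the scatter), which is within the scatter; its furthest is compound 1, separated by a 4.0-fold higher number from compound 1 to compound 3 (0.60 log units; beyond the scatter), which is beyond it. Among the measured compounds shown here, the only other measured step, a 4.6-fold higher number from compound 1 to compound 2 (0.67 log units; beyond the scatter), also moves away from compound 1.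

Compound 4, `O=C(Nc1cccc(-c2oc3cc(-c4ccc(F)cc4)ccc3c(=O)c2O)c1)c1ccc([N+](=O)[O-])cc1`, differs from compound 3 by 4-nitrophenyl in place of 2-methylphenyl on a carbonyl carbon. For the measured compounds named here, none of the measured steps changes a 2-methylphenyl for a 4-nitrophenyl on the carbonyl carbon, so no step bears on it directly. What the numbers do show is that compound 1 alone gives a clearly lower number, while compound 2 and compound 3, which differ from each other in the whole aryl group on the carbonyl carbon, lie together within the scatter. Going by the values given here, with no direct precedent, the account expects compound 4 to stay near compound 3, with a step of a 1.4-fold lower number from compound 3 to compound 4 (0.13 log units; within the scatter) that is not clearly beyond the scatter in either direction. The estimated value for compound 4 in this assay is 13000 nM, with a range from 4000 nM to 40000 nM.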

Compound 4, half-maximal inhibitory concentration: 2440 nM
The estimate for compound 4 lay 5.3-fold (0.73 log units) above the measured number, outside the stated range (below it).
By their numbers in this assay, from the lowest: compounds 4 and 1 (each within the scatter of the next); then compounds 3 and 2 (each within the scatter of the next).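

Among the compounds shown here, on the carbonyl carbon, 4-nitrophenyl gives a result in this assay that the earlier compounds did not foreshadow, with a 7.2-fold lower number from compound 3 to compound 4 (0.86 log units; beyond the scatter) and an 8.4-fold lower number from compound 2 to compound 4 (0.92 log units; beyond the scatter) both beyond the scatter. The step of a 1.8-fold lower number from compound 1 to compound 4 (0.26 log units; within the scatter) lies within the scatter, so compound 1 no longer stands alone at the low end of the numbers, and this position accepts an aryl group carrying a nitro group as well as 2-fluorophenyl, while 2-methylphenyl and 2,4-difluorophenyl stay apart from both. Nothing available accounts for the size of these steps and they are recorded here only as measured differences.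

The four compounds leave open whether the lower numbers of compound 1 and compound 4 have anything in common, since their aryl groups differ in both the substituent and its place on the ring. Also open, from the compounds shown here alone, is where a plain phenyl, a 4-aminophenyl or a 4-methoxyphenyl on the same carbonyl carbon would fall, with compound 4 or with compound 3.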